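The source may report more compounds than this note shows. Statements on the series, on what has been measured and on what is new or still open speak of the compounds shown alone.

Two related natural-product-like compounds have been tested. Compound 1 `C=C1C(=O)[C@@]23COC[C@]4([C@@H](OC(C)=O)CC[C@@](C)(COC(C)=O)[C@H]4CO)[C@@H]2CC[C@@H]1C3` gives, in a functional assay on RAW264.7 cells (Mus musculus) for inhibition (on this read-out lower numbers stand for stronger inhibition and higher numbers for weaker inhibition), a value of 8200 nM. Compound 2 `C=C1C(=O)[C@]23C[C@H]1C[C@@H](O)[C@H]2[C@]1(COC3=O)[C@@H](OC(C)=O)CC[C@@](C)(COC(C)=O)[C@H]1C=O` gives 24200 nM in this assay, the higher of the two numbers, a gap from compound 1 that lies beyond the usual scatter. Compound 3 `C=C1C(=O)[C@]23C[C@H]1CC[C@H]2[C@]1(COC3=O)[C@@H](OC(C)=O)CC[C@@](C)(COC(C)=O)[C@H]1C=O` differs from compound 2 by a single change: hydrogen in place of hydroxy on a saturated ring carbon. Going by the values given here, no pair differing in one place has been measured, so the expected step from compound 2 to compound 3 in this assay, a 1.0-fold higher number from compound 2 to compound 3 (0.01 log units; within the scatter), is small and not clearly beyond the scatter. Compound 3 is estimated at 25000 nM, within 10000 nM to 60000 nM.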

Compound 3, half-maximal inhibitory concentration: 20300 nM
For compound 3 the middle estimate is 1.2-fold (0.09 log units) above the measured one; measured number inside the range.
By their numbers in this assay, from the lowest: compound 1; then compounds 3 and 2 (each within the scatter of the next).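

In this assay, putting hydrogen in place of hydroxy on this saturated ring carbon gives a 1.2-fold lower number from compound 2 to compound 3 (0.08 log units; within the scatter). This first pair differing in one place shows that, on this read-out, the hydroxy at this position can be removed without a change in inhibition that stands out from the scatter. Nothing available here explains this result. The compounds shown leave open whether an amine, a carboxylic acid or a longer chain on this same carbon would move the number. They also leave open whether this swap would behave alike on another core.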